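The source may hold more compounds than are shown below. What is called first, only, known or untested is meant among the compounds shown, and "the series" means these compounds.

Working notes on the series. Compound 2 `CCCCn1nc(Cc2ccc(OC)c(OC)c2)c2ccccc2c1=O` carries a butyl group on the ring nitrogen, and in a functional assay on aorta with Alpha-1D adrenergic receptor (Rattus norvegicus) as the target (a lower number here means that less compound is needed, a higher number that more compound is needed for the effect), compound 2 gives 5400 nM, the only plain number among the results shown. Compound 1 `CSc1ccc(Cc2nn(-c3ccc([N+](=O)[O-])cc3)c(=O)c3ccccc23)cc1` is reported in this assay only as a limit: compound 1 gives > 100000 nM, and that figure is a limit, not a measured value. Compound 3 `COc1ccc(Cc2nn(-c3ccc([N+](=O)[O-])cc3)c(=O)c3ccccc23)cc1OC` differs from compound 2 by 4-nitrophenyl in place of butyl on an aromatic nitrogen. Going by the values given here, no step between two measured compounds covers this change, so the direction can only be read from what the two results show: compound 1, which also carries the 4-nitrophenyl group on that nitrogen, sits at a limit, while compound 2 with butyl gives a number. A loss in this assay well beyond the usual scatter is expected for compound 3 because compound 1 sits at the limit of > 100000 nM in this assay, at which 1 of the 2 values shown sits. Compound 3 is estimated at 40000 nM, with a range of 8000 nM to 200000 nM, and a real chance of a limit only. That estimate corresponds to an expected step of a 7.4-fold higher number from compound 2 to compound 3 (0.87 log units; beyond the scatter).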

Compound 3, half-maximal effective concentration: > 100000 nM
Compound 3: only a limit was reported; the forecaster's own chance of this, stated with the estimate: 50%; middle value at least 2.5-fold (0.39 log units) away from the limit.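

With 3,4-dimethoxyphenyl held in place, replacing butyl with 4-nitrophenyl on the aromatic nitrogen gives, in this assay, an at least 18-fold higher number from compound 2 to compound 3 (1.26 log units; beyond the scatter). Going by these compounds alone, this is the first readable step at this position, and its size is only a lower bound: the result for compound 3 is a limit, not a number. Compound 1 and compound 3, which both carry 4-nitrophenyl on that nitrogen, now both end at a limit, one with 4-(methylsulfanyl)phenyl and the other with 3,4-dimethoxyphenyl on the chain carbon: the limit of > 100000 nM in this assay, at which 2 of the 3 values shown sit.

From the compounds shown here alone, the step between compound 1 and compound 3 cannot be read: both results are limits, so the comparison of 3,4-dimethoxyphenyl with 4-(methylsulfanyl)phenyl stays open. Also open, going by these compounds, is whether the higher number goes with the aromatic ring as such or with its nitro group, and how a plain phenyl, a longer alkyl chain or a chain ending in an amine on that nitrogen would read against butyl in this assay.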